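Growth Inhibition of Thienyl Esters in HeLa Cells

The source may hold more compounds than are shown below. What is called first, only, known or untested is meant among the compounds shown, and "the series" means these compounds.

Compound 1, `COC(=O)c1ccsc1NC(=O)[C@@H]1CCCN1`: > 250 ug/mL in a functional assay on HeLa cells (Homo sapiens) for inhibition; a higher number here means a weaker inhibitor of growth, a lower number a stronger inhibitor of growth (a limit of the assay)
Compound 2, `CCOC(=O)c1ccsc1NC(=O)[C@@H]1CCCN1`: 35.3 ug/mL in this assay
Compound 3, `O=C(Oc1ccccc1)c1ccsc1NC(=O)[C@@H]1CCCN1`: > 250 ug/mL in this assay (a limit of the assay)

The three measured compounds share one core and differ only in the group on the oxygen next to the carbonyl. Compound 1 reaches only the limit of > 250 ug/mL in this assay. Compound 3 likewise reaches only the limit of > 250 ug/mL. For the measured compounds named here, compound 2 gives 35.3 ug/mL, and it stands as the only number in the whole set. Compound 1 and compound 3 sit at a limit, as the limit of > 250 ug/mL in this assay, at which 2 of the 3 values shown sit, shows.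

The measured steps run an at least 7.0-fold lower number from compound 1 to compound 2 (0.85 log units; beyond the scatter) and an at least 7.0-fold higher number from compound 2 to compound 3 (0.85 log units; beyond the scatter); the step from compound 1 to compound 3 is a step that the two limits leave unreadable from compound 1 to compound 3.

Compound 4, `O=C(OCC(F)(F)F)c1ccsc1NC(=O)[C@@H]1CCCN1`, differs from compound 2 as follows: trifluoromethyl in place of methyl on a saturated chain carbon bound to an oxygen next to a carbonyl group. Going by the values given here, no measured step matches this change. Among the compounds with values here, the only number stands with compound 2, and both neighbours with a different ester group sit at the limit, so compound 4 is expected to give a higher number than compound 2, a step of a 3.1-fold higher number from compound 2 to compound 4 (0.49 log units; beyond the scatter) in this assay. The estimate for compound 4 is 110 ug/mL, between 35 ug/mL and 250 ug/mL.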

Compound 4, concentration for 50% growth inhibition: 109 ug/mL
Compound 4: the middle estimate sits 1.0-fold (0.00 log units) above what was measured, and the stated range covers the measured number.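

Trifluoromethyl in place of methyl on a saturated chain carbon bound to an oxygen next to a carbonyl group gives a 3.1-fold higher number from compound 2 to compound 4 (0.49 log units; beyond the scatter) in this assay, so this change weakens growth inhibition but still leaves a readable number. Compound 4 also stands apart from the two esters that stop at a limit, with an at least 2.2-fold lower number from compound 3 to compound 4 (0.36 log units; beyond the scatter) and an at least 2.2-fold lower number from compound 1 to compound 4 (0.36 log units; beyond the scatter), which shows that a readable number at this position is not confined to the ethyl ester of compound 2. Even so, compound 1 and compound 3 still offer only a limit and not a number: the limit of > 250 ug/mL in this assay, at which 2 of the 4 values shown sit.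

From the compounds shown here alone, four ester groups give only a thin picture of this position, and how a longer chain such as propyl, a branched one such as isopropyl, or a benzyl group would behave there remains open. It also remains open whether the ester itself is needed, since the compounds shown do not tell what an amide or a carboxylic acid in its place would do to growth inhibition.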